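This account rests on a few compounds, and the source may have more. Where it says the series, first, only, none or still open, it means among the compounds named here.

Measured so far in an ADME assay on HEK-293T cells (Homo sapiens) for cytotoxicity, read by CCK-8 assay, with a stated time of 48 h; a lower number here means a stronger inhibitor, a higher number a weaker inhibitor:
compound 1, `O=C(COc1cccc2ccc(N3CCCC3)nc12)NCc1ccccc1`, > 100000 nM
compound 2, `CCOc1ccccc1CNC(=O)COc1cccc2ccc(N3CCCC3)nc12`, > 100000 nM

For compound 2 the value > 100000 nM is a limit of the assay, not a number. For compound 1 the value > 100000 nM is likewise a limit and not a number. Compound 2 therefore stands only at the edge of what this assay reports, together with compound 1, both at the limit of > 100000 nM in this assay, at which 2 of the 2 values shown sit. Within the data shown here, the one measured step, a step that the two limits leave unreadable from compound 1 to compound 2, has no readable size because both of its ends sit at the limit of > 100000 nM in this assay, at which 2 of the 2 values shown sit.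

Compound 3, `O=C(COc1cccc2ccc(N3CCCC3)nc12)NCc1ccc(C(F)(F)F)cc1`, differs from compound 2 by 4-(trifluoromethyl)phenyl in place of 2-ethoxyphenyl on a saturated chain carbon bound to an amide-type nitrogen. Among the measured compounds shown here, no measured step matches this change; the only step available, from hydrogen to ethoxy on an aromatic carbon, is unreadable, so the series gives no direction for the new change. With both measured compounds at the limit, compound 3 is expected to stay at that limit as well. The step of a number no higher from compound 2 to compound 3 (the limit leaves the size open) is thus estimated as none beyond the scatter. Compound 3 is estimated at 100000 nM, with a range from 40000 nM to 300000 nM.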

Compound 3, half-maximal inhibitory concentration: > 100000 nM
Compound 3 ended at the assay's limit (the forecaster's own chance of this, stated with the estimate: 80%); the middle value lies on the limit itself.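

Among these compounds, no step among compound 1, compound 2 and compound 3 can be read in this assay, because all three values are limits of the assay and not numbers: the limit of > 100000 nM in this assay, at which 3 of the 3 values shown sit.

The compounds shown leave open how far each of the three lies from that limit, and which change to the shared core, if any, would give a measurable value.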